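Stretching a methoxy group to ethoxy

The compounds below may be only part of what the source reports. "The series", "measured", "known", "first", "only" and "open" are said of these compounds alone.

Values so far in an ADME assay on the whole organism (plasma, strain CD1) for pharmacokinetics, with Mus musculus as the target, at a dose of 200 mg/kg by the oral route (a higher number here means more compound in the circulation at the dose given, a lower number less compound in the circulation), are:
- Compound 1 (`CCOC(=O)c1c(-c2cccc(-c3ccccc3)c2)[nH]c2cc(OC)ccc2c1=O`) gives 1720 ng.h/mL
- Compound 2 (`CCOC(=O)c1c(-c2cccc(OC)c2)[nH]c2cc(OC)ccc2c1=O`) gives 2760 ng.h/mL

Compound 2 carries a 3-methoxyphenyl group, and its value lies within the usual scatter of the value for compound 1, so the two cannot be ranked. Compound 3 (`CCOC(=O)c1c(-c2cccc(OCC)c2)[nH]c2cc(OC)ccc2c1=O`) differs from compound 2 in one place, where 3-methoxyphenyl becomes 3-ethoxyphenyl (methyl in place of hydrogen on a saturated chain carbon bound to an oxygen on an aromatic ring).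

Among the compounds with values here, only one measured step offers any guidance, and it involves a different change, methoxy in place of phenyl on an aromatic carbon. That exchange gave a 1.6-fold higher number from compound 1 to compound 2 (0.21 log units; within the scatter) and stayed within the scatter. With just two values, this is thin evidence, but a single added methyl gives no reason to expect a larger move in either direction. The expected step of a 1.1-fold lower number from compound 2 to compound 3 (0.04 log units; within the scatter) is therefore no more than scatter. In this assay the estimate for compound 3 is 2500 ng.h/mL within an expected range from 1200 ng.h/mL to 5000 ng.h/mL at this dose.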

Compound 3, area under the concentration-time curve: 3670 ng.h/mL
For compound 3 the middle estimate is 1.5-fold (0.17 log units) below the measured one; low and high end bracket the measured number.
By their numbers in this assay, from the lowest: compounds 1, 2 and 3 (each within the scatter of the next, the first and the last beyond it).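

In this assay, stretching methoxy to ethoxy, which adds one methyl on a saturated chain carbon bound to an oxygen on an aromatic ring, gives a 1.3-fold higher number from compound 2 to compound 3 (0.12 log units; within the scatter) and so sets no order between the two compounds. Within the data shown here, the clearer contrast comes from the exchange of phenyl for ethoxy on the aromatic carbon, which gives a 2.1-fold higher number from compound 1 to compound 3 (0.33 log units; beyond the scatter) and is the first step in this small set to pass beyond the scatter, though only modestly, while the exchange of phenyl for methoxy stayed within it. Nothing measured here explains why the ethoxy exchange passes the scatter and the methoxy exchange does not.

Still open, from the compounds shown here alone, is whether a longer chain on the same oxygen, such as propoxy or butoxy, would hold the number at this level, and what an amine or a carboxylic acid on this aromatic carbon would give. A single exposure read-out at one dose also cannot separate how much compound enters the circulation from how quickly it leaves.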